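The compounds below may be only part of what the source reports. "The series", "measured", "known", "first", "only" and "open" are said of these compounds alone.

Measured compounds:
Compound 1, `CCN(CC)CCNS(=O)(=O)c1ccc(-c2ccnc3[nH]ccc23)cc1`: 10000 nM
Compound 2, `CC(=O)OCCNS(=O)(=O)c1ccc(-c2ccnc3[nH]ccc23)cc1`: 8800 nM

In an assay on isolated protein for inhibition of serine/threonine-protein kinase Nek1 (Homo sapiens), read by TR-FRET, with a stated time of 30 min (a lower number here means a stronger inhibitor, a higher number a weaker inhibitor), compound 1 gives 10000 nM and compound 2 gives 8800 nM. Within the data shown here, the one step between them, a 1.1-fold lower number from compound 1 to compound 2 (0.06 log units; within the scatter), replaces diethylamino with acetoxy on the saturated chain and changes nothing that rises above the scatter. Compound 2 therefore holds the lowest of the two numbers, but its gap to compound 1 is within the scatter, so no order between them can be claimed.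

Compound 3, `CN1CCN(S(=O)(=O)c2ccc(-c3ccnc4[nH]ccc34)cc2)CC1`, is not yet measured. It differs from compound 2 in one place: 4-methylpiperazin-1-yl in place of (2-acetoxyethyl)amino on a sulfonyl sulfur. Among the measured compounds shown here, the only measured step that bears on this change is a 1.1-fold lower number from compound 1 to compound 2 (0.06 log units; within the scatter), which shows that exchanging the substituent at the end of the chain left this assay unmoved. For the measured compounds named here, nothing among the measured compounds speaks to the loss of the sulfonamide hydrogen or to closing the substituent into a ring, so the step from compound 2 to compound 3 is expected to be small, with no direction beyond the scatter. Compound 3 is estimated at 10000 nM, in a range of 3000 nM to 30000 nM. The expected step is a 1.1-fold higher number from compound 2 to compound 3 (0.06 log units; within the scatter).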

Compound 3, half-maximal inhibitory concentration: > 10000 nM
Compound 3 ended at the assay's limit; the forecaster's own chance of this, stated with the estimate: 35%; the middle value sits exactly at the limit.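

In this assay compound 3 gives > 10000 nM, which is a limit of the assay and not a number. Where the earlier compounds varied only the end of a chain on the sulfonamide nitrogen, this change reaches the sulfonyl sulfur itself, placing 4-methylpiperazin-1-yl there in place of (2-acetoxyethyl)amino, and the result is an at least 1.1-fold higher number from compound 2 to compound 3 (0.05 log units; that floor lies within the scatter), so a ring with no hydrogen-bond donor at this place did not bring the number down. The other step is a number no lower from compound 1 to compound 3 (the limit leaves the size open) and the series now reaches the end of the assay's range: the limit of > 10000 nM in this assay, at which 1 of the 3 values shown sits.

The change to compound 3 closes a ring and removes the sulfonamide hydrogen in a single step, so the compounds shown cannot separate the two. From the compounds shown here alone, it also remains open whether any group on this chain or at this sulfur can bring the number clearly down, for instance a carboxylic acid at the end of the chain, a longer chain, or a simple piperazine without its methyl group.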